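A Trifluoromethyl Swap on a Series Without Measurable Inhibition

The source may report more compounds than this note shows. Statements on the series, on what has been measured and on what is new or still open speak of the compounds shown alone.

Compound 3 `CCc1cc2ccccc2nc1-c1cc(-c2ccc(C)cc2)no1` is the starting point. In a functional assay on A549 cells (Homo sapiens) for inhibition, read by MTT assay, with a stated time of 24 h (on this read-out higher numbers stand for weaker inhibition and lower numbers for stronger inhibition), compound 3 gives > 100000 nM, which is a limit of the assay rather than a measured number. Its two relatives stand in the same place. Compound 1 `CCc1cc2ccccc2nc1-c1cc(-c2ccccc2)no1` gives > 100000 nM in this assay, again a limit. Compound 2 `CCc1cc2ccccc2nc1-c1cc(-c2ccc(F)cc2)no1` gives > 100000 nM, also a limit. All three values thus sit together at the limit (the limit of > 100000 nM in this assay, at which 3 of the 3 values shown sit).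

The change to compound 4 `CCc1cc2ccccc2nc1-c1cc(-c2ccc(C(F)(F)F)cc2)no1` is trifluoromethyl in place of methyl on an aromatic carbon. For the measured compounds named here, two measured steps touch the same position on the ring, a step that the two limits leave unreadable from compound 1 to compound 3 and a step that the two limits leave unreadable from compound 2 to compound 3, and there is also a step that the two limits leave unreadable from compound 1 to compound 2. None of them can be read as a size; every value behind them is a limit. They show only that exchanging hydrogen, fluoro or methyl at this place has not yet carried any compound into measurable inhibition. The expectation for the step that the limit leaves unreadable from compound 3 to compound 4 is therefore no readable change, with compound 4 most likely remaining at the limit. Compound 4 is estimated at 150000 nM, with a range from 30000 nM to 1000000 nM.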

Compound 4, half-maximal inhibitory concentration: > 100000 nM
Compound 4: a limit, no number; the forecaster's own chance of this, stated with the estimate: 85%; the middle value is on the limit's open side.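

Compound 4 joins compound 1, compound 2 and compound 3 at a limit, so no step among these four compounds can be read as a size: the limit of > 100000 nM in this assay, at which 4 of the 4 values shown sit.

The compounds shown leave open how weak each of them really is in this assay, and whether any other group in this place would give a measurable number.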